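The source may report more compounds than this note shows. Statements on the series, on what has been measured and on what is new or still open speak of the compounds shown alone.

Measured so far in a functional assay on DU-145 cells (Homo sapiens) for cytotoxicity, read by sulforhodamine B assay; on this read-out lower numbers stand for stronger inhibition of growth and higher numbers for weaker inhibition of growth
- compound 1 `COc1ccc2c(c1)C(=O)CCN2c1nc(Cl)nc2ccccc12` gives 31 nM
- compound 2 `COc1ccc2c(c1)CCCCN2c1nc(Cl)nc2ccccc12` gives 165 nM

Compound 2 holds the higher of the two numbers, and its gap to compound 1 lies beyond the usual scatter. The two compounds differ in more than one place, so this gap cannot be assigned to any single structural change.

Next in view is compound 3 `COc1ccc2c(c1)CCCCN2c1nc(C)nc2ccccc12`, which differs from compound 2 by methyl in place of chloro on an aromatic carbon, between two ring nitrogen atoms. For the measured compounds named here, no measured pair isolates a change at this place, so the data offer no direct precedent for its size or direction. In this assay no step beyond the scatter is expected, although the uncertainty remains wide. The estimate starts from compound 2 at 165 nM and leans only slightly upward. The estimated shift (a 1.1-fold higher number from compound 2 to compound 3 (0.04 log units; within the scatter)) stays within the scatter. For compound 3 the estimate is 180 nM (estimated range 50 nM to 650 nM).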

Compound 3, concentration for 50% growth inhibition: 18 nM
Estimate against measurement, compound 3: 10-fold (1.00 log units) above; the measured number lies below the stated range.
By their numbers in this assay, from the lowest: compounds 3 and 1 (each within the scatter of the next); then compound 2.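

In this assay, the aromatic carbon between two ring nitrogen atoms proves to be a sensitive place in the series, with a 9.2-fold lower number from compound 2 to compound 3 (0.96 log units; beyond the scatter) when methyl stands in place of chloro. The exchange swaps one heavy atom for one, and the computed comparison shows no ring, hydrogen-bond donor, hydrogen-bond acceptor or net charge on either side, so a large shift here does not depend on any change in those counts. The result also shows that chloro at this place is not required for a low number on the core of compound 2, although the data shown offer nothing that explains the size or direction of the step.

From the compounds shown here alone, this remains a single pair on one core, so it is open whether methyl in place of chloro would move the number in the same direction or by a similar amount on the core of compound 1. Going by these compounds, it is also open how an amine, a methoxy group or a longer alkyl chain at this place would compare with methyl and chloro.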